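Hydroxyphenyl position on the shared core: compound 3 to compound 4

The source may hold more compounds than are shown below. What is called first, only, known or untested is meant among the compounds shown, and "the series" means these compounds.

Compound 1 `Oc1ccc(-c2cc(-c3ccsc3)cc(-c3cccc(O)c3)n2)cc1` and compound 2 `Oc1ccc(-c2cc(-c3ccoc3)cc(-c3cccc(O)c3)n2)cc1` both carry a 3-hydroxyphenyl group. In a functional assay on T47D cells (Homo sapiens) for cytotoxicity, read by CCK-8 assay (on this read-out lower numbers stand for stronger inhibition and higher numbers for weaker inhibition), compound 1 gives 760 nM and compound 2 gives 2610 nM, the one listed step being a 3.4-fold higher number from compound 1 to compound 2 (0.54 log units; beyond the scatter). Compound 3 `Oc1ccc(-c2cc(-c3ccccn3)cc(-c3ccccc3O)n2)cc1` carries a 2-hydroxyphenyl group and a pyridin-2-yl group; in this assay compound 3 reaches only the limit of the assay, > 50000 nM, so that it stands at the limit of > 50000 nM in this assay, at which 1 of the 3 values shown sits, and no number is known for it. Compound 4 `Oc1ccc(-c2cc(-c3ccccn3)cc(-c3cccc(O)c3)n2)cc1` is the next member: 3-hydroxyphenyl in place of 2-hydroxyphenyl on an aromatic carbon. Going by the values given here, no measured step concerns either this change or the pyridin-2-yl group, so the only bearing on it is indirect: compound 1 and compound 2, which hold the 3-hydroxyphenyl group, give numbers, while compound 3, with the 2-hydroxyphenyl group, gives none. From this the step from compound 3 to compound 4 is expected to go toward stronger inhibition, an at least 3.3-fold lower number from compound 3 to compound 4 (0.52 log units; beyond the scatter), though a limit remains possible. For compound 4 the estimate in this assay is 15000 nM, expected to lie between 3000 nM and 60000 nM.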

Compound 4, half-maximal inhibitory concentration: 980 nM
For compound 4 the middle estimate is 15-fold (1.18 log units) above the measured one; measured number outside the range, below it.
By their numbers in this assay, from the lowest: compounds 1 and 4 (each within the scatter of the next); then compound 2. At a limit, above all of these: compound 3.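

In this assay, with pyridin-2-yl held fixed, 3-hydroxyphenyl in place of 2-hydroxyphenyl next to the ring nitrogen gives a large change: an at least 51-fold lower number from compound 3 to compound 4 (1.70 log units; beyond the scatter). Compound 3 holds a limit of the assay and not a number: the limit of > 50000 nM in this assay, at which 1 of the 4 values shown sits. With 3-hydroxyphenyl held fixed, pyridin-2-yl in place of furan-3-yl gives a 2.7-fold lower number from compound 2 to compound 4 (0.43 log units; beyond the scatter), and pyridin-2-yl in place of thiophen-3-yl gives a 1.3-fold higher number from compound 1 to compound 4 (0.11 log units; within the scatter), so a pyridin-2-yl group can coexist with a measured number.

From the compounds shown here alone, whether 2-hydroxyphenyl has a similar effect alongside thiophen-3-yl or furan-3-yl remains open. Also open, going by these compounds, is whether the hydroxyl of the 3-hydroxyphenyl group is needed at all, as a 3-methoxyphenyl or 3-aminophenyl group in the same place would show.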